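The source may hold more compounds than are shown below. What is called first, only, known or untested is meant among the compounds shown, and "the series" means these compounds.

Measured so far in a functional assay on Ehrlich cells (Mus musculus) for cytotoxicity, tested at 100 ug/mL; a higher number here means a stronger effect of the compound at the concentration tested, a lower number a weaker effect:
compound 1 `COc1cc(N2C(N)=C(C#N)C(c3ccccc3O)C3=C2CC(C)(C)CC3=O)cc(OC)c1OC` gives 10%
compound 2 `COc1cc(N2C(N)=C(C#N)C(c3c(O)ccc4ccccc34)C3=C2CC(C)(C)CC3=O)cc(OC)c1OC` gives 90%
compound 3 `COc1cc(N2C(N)=C(C#N)C(c3ccc(Cl)cc3Cl)C3=C2CC(C)(C)CC3=O)cc(OC)c1OC` gives 100%

Compound 1 stands lowest of the three numbers; compound 2 is nearest to it and compound 3 furthest. Compound 4 `COc1cc(N2C(N)=C(C#N)C(c3ccc(C)o3)C3=C2CC(C)(C)CC3=O)cc(OC)c1OC` differs from compound 1 in one place: 5-methylfuran-2-yl in place of 2-hydroxyphenyl on a saturated ring carbon. Within the data shown here, two measured steps bear on this change, both replacing the same 2-hydroxyphenyl on a saturated ring carbon of the core of compound 1: a number 80 percentage points higher from compound 1 to compound 2 (beyond the scatter), and a number 90 percentage points higher from compound 1 to compound 3 (beyond the scatter). Both replacements gave large rises, so a rise beyond the scatter is expected here too; the entering 5-methylfuran-2-yl matches neither earlier group, so the size is uncertain. The expected step is a number 55 percentage points higher from compound 1 to compound 4 (beyond the scatter). Compound 4 is thus estimated at 65%, in the range 25% to 95%.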

Compound 4, a percentage reported as activity, at one concentration (the size of the read-out at that concentration, not a potency): 50%
Beside the measured number, compound 4's estimate is 15 percentage points above it; the measured number falls inside the stated range.
By their numbers in this assay, from the lowest: compound 1; then compound 4; then compounds 2 and 3 (each within the scatter of the next).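

In this assay, the saturated ring carbon now shows a middle level: the five-membered aromatic ring of 5-methylfuran-2-yl gives a number 40 percentage points higher from compound 1 to compound 4 (beyond the scatter) and still leaves a number 50 percentage points lower from compound 3 to compound 4 (beyond the scatter) as well as a number 40 percentage points lower from compound 2 to compound 4 (beyond the scatter). Losing 2-hydroxyphenyl alone therefore does not bring the full rise, and the entering group affects its size.

No available evidence accounts for these differences between groups. From the compounds shown here alone, whether a furan-2-yl without the methyl, or a benzylic amine at this position, would retain the effect remains open.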